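The source may hold more compounds than are shown below. What is called first, only, known or untested is meant among the compounds shown, and "the series" means these compounds.

Compound 1 `O=C(Nc1ccc2c(c1)N(Cc1ccc(C(=O)NO)cc1)CC2)Nc1ccc(Cl)c(C(F)(F)F)c1`: 4500 nM
Compound 2 `O=C(Nc1ccc(C(=O)NO)cc1)Nc1ccc(Cl)c(C(F)(F)F)c1`: 3800 nM
Compound 3 `O=C(Nc1ccc2c(c1)CCCN2Cc1ccc(C(=O)NO)cc1)Nc1ccc(Cl)c(C(F)(F)F)c1`: 4500 nM

These three compounds were compared in a functional assay on SK-HEP1 cells (Homo sapiens) for inhibition, read by sulforhodamine B assay, with a stated time of 48 h; on this read-out higher numbers stand for weaker inhibition and lower numbers for stronger inhibition. Compound 2, at 3800 nM, lies within the usual scatter of both other compounds, so the data do not separate the three, even though compound 2 is visibly smaller than the other two.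

The next compound to be tested is compound 4 `O=C(/C=C/c1ccc(NC(=O)Nc2ccc(Cl)c(C(F)(F)F)c2)cc1)NO`. It keeps the rest of compound 2 but has 2-(hydroxycarbamoyl)ethenyl in place of hydroxycarbamoyl on an aromatic carbon.

Among the measured compounds shown here, no measured pair shows the effect of this change, so any forecast is uncertain. For the measured compounds named here, the only guide is that compound 2 at 3800 nM and compound 1 at 4500 nM sit within the scatter despite their different structures. A large step in this assay therefore seems unlikely, and a shift towards a slightly lower number, within the scatter, is expected.

The expected change is a 1.5-fold lower number from compound 2 to compound 4 (0.18 log units; within the scatter).

The estimate for compound 4 is 2500 nM, with an expected range from 700 nM to 6500 nM.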

Compound 4, half-maximal inhibitory concentration: 3200 nM
The estimate for compound 4 lay 1.3-fold (0.11 log units) below the measured number; the measured number falls inside the stated range.
By their numbers in this assay, from the lowest: compounds 4, 2, 1 and 3 (each within the scatter of the next).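

In this assay, among the compounds shown here, this is the first pair of compounds that differ in one place, and the step of a 1.2-fold lower number from compound 2 to compound 4 (0.07 log units; within the scatter) comes with 2-(hydroxycarbamoyl)ethenyl in place of hydroxycarbamoyl on an aromatic carbon, para to a large group. The entering group has 6 heavy atoms against 4 and the same counts of hydrogen-bond donors and acceptors, so at this position a longer group carrying the hydroxycarbamoyl end leaves the number within the scatter. Nothing at hand explains why the number stays there.

Still open, from the compounds shown here alone, is whether a longer chain ending in hydroxycarbamoyl, or a carboxylic acid or an amine in its place, would move the number beyond the scatter. Also open, going by these compounds, is whether the same change would give a similar step on the cores of compound 1 and compound 3.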